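The source may hold more compounds than are shown below. What is called first, only, known or untested is meant among the compounds shown, and "the series" means these compounds.

Measured so far in an assay on cells for inhibition of cytochrome P450 11B2, mitochondrial (Homo sapiens); on this read-out lower numbers stand for stronger inhibition and higher numbers for weaker inhibition:
compound 1 `C[C@@H](c1ccc(Cl)cc1)N1Cc2cncn2C(C[C@@H](O)c2ccccc2)S1(=O)=O` gives 2.4 nM
compound 2 `C[C@@H](c1ccc(Cl)cc1)N1Cc2cncn2C(C[C@H](O)c2ccccc2)S1(=O)=O` gives 0.3 nM
compound 3 `COC(C)(C)CC1n2cncc2CN([C@@H](C)c2ccc(Cl)cc2)S1(=O)=O` gives 0.9 nM

Compound 3 holds the middle number of the three: from compound 1 there is a 2.7-fold lower number from compound 1 to compound 3 (0.43 log units; beyond the scatter), and from compound 2 there is a 3.0-fold higher number from compound 2 to compound 3 (0.48 log units; beyond the scatter), both steps beyond the scatter. The step of an 8.0-fold lower number from compound 1 to compound 2 (0.90 log units; beyond the scatter) goes with the fact that one of compounds 1 and 2 is drawn with a defined configuration and the other without, at the place where they differ and shows how much the group on the saturated chain carbon can move the number even when the atoms stay the same.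

Compound 4 `CC(C)CC1n2cncc2CN([C@@H](C)c2ccc(Cl)cc2)S1(=O)=O` is not yet measured. Against compound 3 the change is hydrogen in place of methoxy on a saturated chain carbon bound to three saturated chain carbons; cut one bond further out it reads 1-methoxy-1-methylethyl to isopropyl. Going by the values given here, no measured pair makes this exact change. The nearest guides are the two steps into compound 3 from compound 1 and compound 2, which swap the whole group at this position and move the number by modest amounts in either direction. Removing only the methoxy is a smaller change than either of those, so in this assay a step within or just beyond the scatter is expected, with a slight lean towards a higher number.

Compound 4 is therefore expected at 2 nM, in the range 0.6 nM to 6 nM. This means an expected step of a 2.2-fold higher number from compound 3 to compound 4 (0.35 log units; beyond the scatter).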

Compound 4, half-maximal inhibitory concentration: 9.4 nM
Compound 4: middle estimate off by 4.7-fold (0.67 log units), on the low side; measured number outside the range, above it.
By their numbers in this assay, from the lowest: compound 2; then compound 3; then compound 1; then compound 4.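

In this assay the loss of the methoxy alone, on a saturated chain carbon bound to three saturated chain carbons, proves to be no minor edit: a 10-fold higher number from compound 3 to compound 4 (1.02 log units; beyond the scatter), a large step, whereas the earlier swaps of the whole group at this position were modest. Isopropyl also stands above both hydroxy(phenyl)methyl compounds, with a 31-fold higher number from compound 2 to compound 4 (1.50 log units; beyond the scatter) and a 3.9-fold higher number from compound 1 to compound 4 (0.59 log units; beyond the scatter), so among the four compounds compound 4 has the highest number and the 1-methoxy-1-methylethyl group of compound 3 cannot be treated as interchangeable with isopropyl. The data at hand offer no explanation for the size of this step, as the only available observation concerns the stereo difference between compounds 1 and 2 and does not touch the methoxy.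

The compounds shown leave open whether the step follows the oxygen or the whole methoxy, a question that a hydroxy or an ethoxy on the same carbon would address. They also leave open how an amine such as dimethylamino, or a longer chain such as a 2-methoxyethyl group, would read at this carbon.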